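The source may hold more compounds than are shown below. What is called first, only, known or untested is meant among the compounds shown, and "the series" means these compounds.

Compound 1 `CN(C)CCn1cnnc1-c1cc(Oc2ccc(NC(=O)Nc3cccc(C(F)(F)F)c3)cc2F)ccn1` serves as the reference in this set. In a functional assay on MDA-MB-231 cells (Homo sapiens) for antiproliferative activity, read by MTT assay, with a stated time of 72 h (a higher number here means a weaker inhibitor, a lower number a stronger inhibitor), compound 1 gives 16400 nM. Compound 2 `CN(C)CCn1cnnc1-c1cc(Oc2ccc(NC(=O)Nc3ccccc3C(F)(F)F)cc2F)ccn1` differs from compound 1 in one place, the change being (2-(trifluoromethyl)phenyl in place of 3-(trifluoromethyl)phenyl on an amide-type nitrogen). For compound 2 the result in this assay is a limit of the assay, > 50000 nM. The step from compound 1 to compound 2 is therefore known only in one direction, an at least 3.0-fold higher number from compound 1 to compound 2 (0.48 log units; beyond the scatter), and its open-ended form rests on (the limit of > 50000 nM in this assay, at which 1 of the 3 values shown sits).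

Compound 3 `CN(C)CCCn1cnnc1-c1cc(Oc2ccc(NC(=O)Nc3cccc(C(F)(F)F)c3)cc2F)ccn1` carries a different core; the difference between the core of compound 1 and the core of compound 3 is (dimethylamino)methyl in place of dimethylamino on a saturated chain carbon, two bonds along the chain from an aromatic nitrogen. In this assay compound 3 gives 13300 nM. The step is a 1.2-fold lower number from compound 1 to compound 3 (0.09 log units; within the scatter), so compound 1 and compound 3 cannot be separated by this measurement.

Compound 4 `CN(C)CCCn1cnnc1-c1cc(Oc2ccc(NC(=O)Nc3ccccc3C(F)(F)F)cc2F)ccn1` has not yet been measured. It differs from compound 3 by 2-(trifluoromethyl)phenyl in place of 3-(trifluoromethyl)phenyl on an amide-type nitrogen. This is the same change, at the same place, that was made once before, where it gave an at least 3.0-fold higher number from compound 1 to compound 2 (0.48 log units; beyond the scatter). Since compound 3 in this assay sits within the scatter of compound 1, the step from compound 3 to compound 4 is expected to be of similar size, a 4.5-fold higher number from compound 3 to compound 4 (0.65 log units; beyond the scatter), with a substantial chance that only a limit is reported. Compound 4 is thus estimated at 60000 nM in this assay, with an expected range from 30000 nM to 150000 nM.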

Compound 4, half-maximal inhibitory concentration: 40500 nM
Compound 4: middle estimate off by 1.5-fold (0.17 log units), on the high side; the measured number falls inside the stated range.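

On the core of compound 3, 2-(trifluoromethyl)phenyl in place of 3-(trifluoromethyl)phenyl on the amide-type nitrogen again gives a weaker result in this assay, a 3.0-fold higher number from compound 3 to compound 4 (0.48 log units; beyond the scatter), so the direction of the change seen on the core of compound 1 carries over to this second core: the same change on two cores in this assay, an at least 3.0-fold higher number (0.48 log units; beyond the scatter) from compound 1 to compound 2 and a 3.0-fold higher number (0.48 log units; beyond the scatter) from compound 3 to compound 4; the limit leaves it open whether they differ

Compound 2 has only a limit of the assay, > 50000 nM, so the size of the change on the core of compound 1 is known as a floor alone, and the data do not show that the change has the same size on both cores: the limit of > 50000 nM in this assay, at which 1 of the 4 values shown sits.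

The step in the other direction, with (dimethylamino)methyl in place of dimethylamino, an at least 1.2-fold lower number from compound 2 to compound 4 (0.09 log units; that floor lies within the scatter), rests on that same limit and cannot show whether this chain change behaves alike with both aryl groups: the same change on two cores in this assay, a 1.2-fold lower number (0.09 log units; within the scatter) from compound 1 to compound 3 and an at least 1.2-fold lower number (0.09 log units; that floor lies within the scatter) from compound 2 to compound 4; the limit leaves it open whether they differ

The compounds shown leave open whether the change would carry over to a core with a pyrrolidine or a morpholine in place of the dimethylamino group, or with a longer chain. They also leave open how an unsubstituted phenyl or a chlorophenyl on the amide-type nitrogen would compare with the two trifluoromethyl-bearing groups.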